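The compounds below may be only part of what the source reports. "The series", "measured", "known", "first", "only" and "open" are said of these compounds alone.

Measured compounds:
compound 1 `CCCc1cn(C/C=C(/C)CCC=C(C)C)nn1` gives 4.05 in a physicochemical assay for lipophilicity, measured as octanol-water partition; on this read-out higher numbers stand for higher lipophilicity and lower numbers for lower lipophilicity;
compound 2 `CCCc1cn(C/C=C(/C)CC/C=C(\C)CCC=C(C)C)nn1` gives 6.5;
compound 3 `COC(=O)c1cn(CC=C(C)C)nn1` gives 1.3, the lowest of the three.

Compound 2 grows out of compound 1 by one change, (3-methylbut-2-en-1-yl in place of hydrogen on a saturated chain carbon bound to a double-bonded chain carbon). That step made a number 2.45 log units higher from compound 1 to compound 2 (beyond the scatter). Compound 4 `COC(=O)c1cn(C/C=C(\C)CCC=C(C)C)nn1`, not yet measured in this assay, grows out of compound 3 by the same change, (3-methylbut-2-en-1-yl in place of hydrogen on a saturated chain carbon bound to a double-bonded chain carbon), at the same place. The cores of compound 3 and compound 1 differ, but that difference is not broken down here; their values show compound 3 well lower than compound 1 in this assay.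

Within the data shown here, since the one measured example of this change is the step of a number 2.45 log units higher from compound 1 to compound 2 (beyond the scatter), the step from compound 3 to compound 4 is expected to be about as large, a number 2.40 log units higher from compound 3 to compound 4 (beyond the scatter). Compound 4 is therefore estimated to give 3.7, between 3 and 4.4.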

Compound 4, partition coefficient: 3.2
Compound 4: middle estimate off by 0.50 log units, on the high side; the measured number falls inside the stated range.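

The same change gives a number 1.90 log units higher from compound 3 to compound 4 (beyond the scatter) in this assay and a number 2.45 log units higher from compound 1 to compound 2 (beyond the scatter) on the other core. It therefore carried from one core to the other here: the number rose both times, and both steps are large. Two cores are only two examples, so this sets no general rule for the series, and nothing shown explains the size of either step.

The compounds shown leave open whether the change would give a similar step on a core carrying a carboxylic acid or an amine. They also leave open how a hexyl chain would compare with 3-methylbut-2-en-1-yl at the same place.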